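This account rests on a few compounds, and the source may have more. Where it says the series, first, only, none or still open, it means among the compounds named here.

Compound 1 `CN(C)CCCCOc1ccc2oc(-c3ccccc3)cc(=O)c2c1` stands highest of the three measured numbers, and therefore as the weakest inhibitor among them: in an assay on isolated protein (Cavia porcellus) with Sigma non-opioid intracellular receptor 1 (Homo sapiens) as the target, read by radioligand binding (on this read-out lower numbers stand for stronger inhibition and higher numbers for weaker inhibition), compound 1 gives 720 nM. Compound 2 `O=c1cc(-c2cccnc2)oc2ccc(OCCCCCCN3CCC(O)CC3)cc12` gives 194 nM and compound 3 `O=c1cc(-c2cccnc2)oc2ccc(OCCCCCCN3CCCCC3)cc12` gives 119 nM, both beyond the scatter from compound 1. Within the data shown here, the only single-point step measured is a 1.6-fold lower number from compound 2 to compound 3 (0.21 log units; within the scatter), a change of a hydroxy on a saturated ring. Compound 4 `NCCCCCCOc1ccc2oc(-c3ccccc3)cc(=O)c2c1` is the unmeasured compound; relative to compound 1 the change is 2-aminoethyl in place of dimethylamino on a saturated chain carbon, four bonds along the chain from an oxygen on an aromatic ring. Among the measured compounds shown here, no measured step alters the amine itself or lengthens the chain on its own: compound 2 and compound 3 differ from compound 1 in several places at once, so their lower numbers cannot be assigned to any one of those differences, and the single measured step is within the scatter and touches a different part of the molecule. For the measured compounds named here, with no direct precedent, the expectation for compound 4 is a number close to that of compound 1, with a 1.3-fold higher number from compound 1 to compound 4 (0.10 log units; within the scatter) expected to stay small. Compound 4 is estimated at 900 nM, between 250 nM and 3200 nM.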

Compound 4, half-maximal inhibitory concentration: 2100 nM
For compound 4 the middle estimate is 2.3-fold (0.37 log units) below the measured one; low and high end bracket the measured number.
By their numbers in this assay, from the lowest: compounds 3 and 2 (each within the scatter of the next); then compound 1; then compound 4.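

This is the first change shown at the amine end of the chain: the same atoms, joined differently, turn dimethylamino into 2-aminoethyl, which carries a hydrogen-bond donor that dimethylamino lacks. In this assay the change gives a 2.9-fold higher number from compound 1 to compound 4 (0.46 log units; beyond the scatter) and so weakens inhibition, which shows that this end of the chain is not indifferent to how these atoms are arranged. No outside evidence bears on why this happens.

Among these compounds, the single step moves the amine further along the chain and removes its methyl groups together, so the share of each remains open. A methylamino group at the end of the chain of compound 1, or a dimethylamino group on the longer chain of compound 4, would separate the two.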